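From cyclopentyl to 2-methylphenyl on an amide-type nitrogen

The source may hold more compounds than are shown below. What is called first, only, known or untested is meant among the compounds shown, and "the series" means these compounds.

Measured in a functional assay on HepG2 cells (Homo sapiens) for antiproliferative activity, read by MTT assay, with a stated time of 48 h; on this read-out higher numbers stand for weaker inhibition and lower numbers for stronger inhibition:
- compound 1 `O=C(Nc1cccc(Cl)c1)Nc1cccc(CNc2nccnc2Cl)c1`: 9140 nM
- compound 2 `Cc1ccc(NC(=O)Nc2cccc(CNc3nccnc3Cl)c2)c(C)c1`: 9290 nM
- compound 3 `O=C(Nc1cccc(CNc2nccnc2Cl)c1)NC1CCCC1`: 18400 nM

At 18400 nM compound 3 stands within the scatter of the other two, as the measurements show a 2.0-fold higher number from compound 1 to compound 3 (0.30 log units; within the scatter) and a 2.0-fold higher number from compound 2 to compound 3 (0.30 log units; within the scatter) on the same scale. The next compound, compound 4 `Cc1ccccc1NC(=O)Nc1cccc(CNc2nccnc2Cl)c1`, differs from it by one group: 2-methylphenyl in place of cyclopentyl on an amide-type nitrogen puts 2-methylphenyl in place of cyclopentyl on an amide-type nitrogen.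

Going by the values given here, three measured steps bear on this change. Two of them swap an aromatic group for cyclopentyl at this place, the steps already given, and both stay within the scatter. The third, a 1.0-fold higher number from compound 1 to compound 2 (0.01 log units; within the scatter), exchanges one aromatic group for another and shows no change. Compound 4 is therefore expected to fall close to compound 1 and compound 2, with no step beyond the scatter in this assay. The estimated step is a 1.8-fold lower number from compound 3 to compound 4 (0.26 log units; within the scatter) and would run towards a lower number, if it shows at all. Compound 4 is estimated at 10000 nM, with an expected range from 5000 nM to 20000 nM.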

Compound 4, half-maximal inhibitory concentration: 15300 nM
Beside the measured number, compound 4's estimate is 1.5-fold (0.18 log units) below it; low and high end bracket the measured number.
By their numbers in this assay, from the lowest: compounds 1, 2, 4 and 3 (each within the scatter of the next).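

In this assay, 2-methylphenyl in place of cyclopentyl gives a 1.2-fold lower number from compound 3 to compound 4 (0.08 log units; within the scatter), so this further aromatic group, carrying a single methyl, is not separated from the non-aromatic ring at the amide-type nitrogen. Going by these compounds alone, the comparisons with the other aromatic groups read the same way: the change from 2,4-dimethylphenyl gives a 1.6-fold higher number from compound 2 to compound 4 (0.22 log units; within the scatter), and the change from 3-chlorophenyl gives a 1.7-fold higher number from compound 1 to compound 4 (0.22 log units; within the scatter), so no step among the four compounds lies beyond the scatter. No supporting evidence bears on why these groups stay so close.

From the compounds shown here alone, all four groups at this nitrogen are carbon rings, with or without a chlorine or methyl substituent, so it remains open whether a ring bearing an amine or a carboxylic acid, or a longer chain in place of the ring, would move the number beyond the scatter. The shared core is also the same throughout, which leaves the effect of any change there unknown.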